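Carbonyl-side variation in a cAMP efficacy series

The source may report more compounds than this note shows. Statements on the series, on what has been measured and on what is new or still open speak of the compounds shown alone.

Measured so far in a functional assay on isolated protein for inhibition of Glucose-dependent insulinotropic receptor (Rattus norvegicus), read by HTRF and cAMP accumulation; on this read-out higher numbers stand for larger maximal responses and lower numbers for smaller maximal responses:
Compound 1 `Cc1nc(S(C)(=O)=O)ccc1Oc1ncnc(OC2CCN(C(=O)OC(C)(C)C(F)(F)F)CC2)c1F` gives 79%.
Compound 2 `Cc1nc(S(C)(=O)=O)ccc1Oc1ncnc(OC2CCN(C(=O)O[C@@H](C)CF)CC2)c1F` gives 84%.
Compound 3 `Cc1nc(S(C)(=O)=O)ccc1Oc1ncnc(OC2CCN(C(=O)OC3(C(F)(F)F)COC3)CC2)c1F` gives 84%.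

Compound 2 stands level with compound 3 at the digits printed, the two together the highest of the three numbers, and the remaining measured gap is a number 5 percentage points higher from compound 1 to compound 2 (within the scatter), within the scatter. Every measured step sits on the oxygen next to the carbonyl group: a number 5 percentage points higher from compound 1 to compound 3 (within the scatter) and no change at the digits printed from compound 2 to compound 3 (within the scatter), none beyond the scatter.

Compound 4 `Cc1nc(S(C)(=O)=O)ccc1Oc1ncnc(OC2CCN(C(=O)c3nc(C(C)(C)F)no3)CC2)c1F` differs from compound 2 by a group of 9 heavy atoms (5 carbon, 2 nitrogen, 1 oxygen, 1 fluorine; one five-membered aromatic ring with 3 hetero atoms) in place of a group of 5 heavy atoms (3 carbon, 1 oxygen, 1 fluorine; no ring), on a carbonyl carbon. Among the measured compounds shown here, no measured step alters the carbonyl carbon itself, so no direct precedent exists; the three flat steps suggest no step beyond the scatter is expected, a number 2 percentage points lower from compound 2 to compound 4 (within the scatter). Compound 4 is therefore estimated at 82%, expected between 70% and 94%.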

Compound 4, largest response reached (reported as efficacy), in percent of the reference or control that the assay uses: 84%
Estimate against measurement, compound 4: 2 percentage points below; the measured number falls inside the stated range.
By their numbers in this assay, from the lowest: compounds 1, 2, 3 and 4 (each within the scatter of the next).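

In this assay, the five-membered aromatic ring with 3 hetero atoms changes the group on the carbonyl carbon itself, and the read-out stays flat (no change at the digits printed from compound 2 to compound 4 (within the scatter); no change at the digits printed from compound 3 to compound 4 (within the scatter); a number 5 percentage points higher from compound 1 to compound 4 (within the scatter)). The absence of any step beyond the scatter now extends from groups on the oxygen to this ring group on the carbonyl carbon. Among the compounds shown here, no evidence accompanying these compounds bears on this result.

As far as these compounds go, whether an amine or a carboxylic acid on the carbonyl carbon would give a step beyond the scatter remains open. From the compounds shown here alone, the effect of changes elsewhere on the shared core also remains open.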